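Cytotoxicity Screen: Dichlorophenyl Taking the Place of Pyridinyl

This account rests on a few compounds, and the source may have more. Where it says the series, first, only, none or still open, it means among the compounds named here.

Measured compounds in an ADME assay on HepG2 cells (Homo sapiens) for cytotoxicity, read by CellTiter-Glo and resazurin assay, with a stated time of 72 h; a lower number here means that less compound is needed, a higher number that more compound is needed for the effect:
compound 1 `CC(C)N(Cc1cccc(OCCCCCC(=O)O)c1)C(=O)c1ccc(-c2ccc3cc[nH]c3c2)cc1` gives > 26000 nM, a limit of the assay.
compound 2 `CC(C)N(Cc1cccc(OCCCCCC(=O)O)c1)C(=O)c1ccc(-c2cccc(F)c2)cc1` gives > 26000 nM, a limit of the assay.
compound 3 `CCOC(=O)CCCCCOc1cccc(CN(C(=O)c2ccc(-c3cccnc3)cc2)C(C)C)c1` gives > 26000 nM, a limit of the assay.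

Within the data shown here, the one measured step, a step that the two limits leave unreadable from compound 1 to compound 2, stays unreadable because of the limit of > 26000 nM in this assay, at which 3 of the 3 values shown sit. Compound 3 stands at that same limit, with no number to compare against. Compound 4 `CCOC(=O)CCCCCOc1cccc(CN(C(=O)c2ccc(-c3ccc(Cl)c(Cl)c3)cc2)C(C)C)c1` differs from compound 3 by 3,4-dichlorophenyl in place of pyridin-3-yl on an aromatic carbon. Among the measured compounds shown here, no measured step bears on this change, and the values shown give no size for it in either direction. Compound 4 is therefore expected to sit at the limit again, with an expected step that the limit leaves unreadable from compound 3 to compound 4 within the scatter. The estimate for compound 4 in this assay is 30000 nM, ranging from 12000 nM to 80000 nM.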

Compound 4, half-maximal effective concentration: > 26000 nM
Compound 4: no number, only a limit; the forecaster's own chance of this, stated with the estimate: 80%; the middle value does not contradict the limit.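

No step can be read from compound 3 to compound 4, because both stand at a limit of the assay: the limit of > 26000 nM in this assay, at which 4 of the 4 values shown sit. On these data alone, the size and direction of any effect of 3,4-dichlorophenyl in place of pyridin-3-yl in this assay remain open.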